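The compounds below may be only part of what the source reports. "The series", "measured", "known", "first", "only" and "open" are said of these compounds alone.

Measured so far:
compound 1, `O=c1c(CSC(=S)N2CCN(c3ccccc3)CC2)coc2ccccc12`, 7100 nM;
compound 2, `CC(C)N(C(=S)SCc1oc2ccccc2c(=O)c1Cl)C(C)C`, > 40000 nM.

Two compounds carry numbers in a functional assay on HeLa cells (Homo sapiens) for antiproliferative activity, read by MTT assay, with a stated time of 72 h; a higher number here means a weaker inhibitor, a lower number a stronger inhibitor. Compound 1, `O=c1c(CSC(=S)N2CCN(c3ccccc3)CC2)coc2ccccc12`, gives 7100 nM in this assay. Compound 2, `CC(C)N(C(=S)SCc1oc2ccccc2c(=O)c1Cl)C(C)C`, is a different matter: in this assay compound 2 gives only > 40000 nM, which is a limit of the assay and not a number. That is where compound 2 stands, and it is the only thing known about it here: the limit of > 40000 nM in this assay, at which 1 of the 2 values shown sits. Among the compounds with values here, no step between measured compounds is available, so what compound 1 and compound 2 show side by side is that one has a number and the other does not.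

Compound 3, `O=c1c(Cl)c(CSC(=S)N2CCOCC2)oc2ccccc12`, has not been measured. It differs from compound 2 in one place: morpholin-4-yl in place of diisopropylamino on a thiocarbonyl carbon. With nothing but a limit to start from, the direction of the step cannot be fixed from the data. Compound 3 is expected to come out around 20000 nM in this assay, somewhere between 5000 nM and 60000 nM. That expectation for compound 3 means a step of an at least 2.0-fold lower number from compound 2 to compound 3 (0.30 log units; that floor lies within the scatter), and a fair chance remains that this assay again reports only a limit.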

Compound 3, half-maximal inhibitory concentration: 4500 nM
Estimate against measurement, compound 3: 4.4-fold (0.65 log units) above; measured number below the stated range.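

Within the data shown here, the change from diisopropylamino to morpholin-4-yl on a thiocarbonyl carbon gives the first step that can be read in this assay, and it is an at least 8.8-fold lower number from compound 2 to compound 3 (0.94 log units; beyond the scatter). With the rest of the two structures the same, the group on this carbon is enough on its own to separate a compound that returns a number from one that returns only a limit. Going by these compounds, the true size of the step remains unknown, and what is printed is only a floor, because the entry for compound 2 is a limit of the assay and not a number: the limit of > 40000 nM in this assay, at which 1 of the 3 values shown sits.

The compounds shown leave open whether the ring of morpholin-4-yl or its oxygen goes with the lower number, a question that piperidin-1-yl, which keeps a six-membered ring without the oxygen, would address at this place on the core of compound 3. Compound 1 differs from compound 3 in more than one place, so it says nothing about this change, and how far other amines on the thiocarbonyl carbon would move the number remains unsettled.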